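The source may report more compounds than this note shows. Statements on the series, on what has been measured and on what is new or still open speak of the compounds shown alone.

Measured compounds:
compound 1, `O=c1c2cnn(-c3ccc(F)cc3)c2ncn1CC1(O)CCN(Cc2ccncc2)CC1`: "not determined" (no result reported)
compound 2, `COC(=O)c1ccc(CN2CCC(O)(Cn3cnc4c(cnn4-c4ccc(F)cc4)c3=O)CC2)cc1`: 4500 nM

Going by these compounds, compound 1 stands without a number in an assay on Sf21 cells for inhibition of ubiquitin carboxyl-terminal hydrolase 7 (Homo sapiens), read by spectrophotometry, with stated times of 30 min and 2 h (on this read-out higher numbers stand for weaker inhibition and lower numbers for stronger inhibition), so its place on this scale is unknown. Compound 3, `COC(=O)c1ccc(CN2CCC(O)(Cn3cnc4c(cnn4-c4ccc(F)cc4)c3=O)CC2)c(Cl)c1`, is reached from compound 1 by the change (2-chloro-4-(methoxycarbonyl)phenyl in place of pyridin-4-yl on a saturated chain carbon bound to an amine nitrogen in a ring). With no value for compound 1, the size and direction of this step in this assay cannot be stated. Compound 3 shares its methoxycarbonyl benzyl part with compound 2, which in this assay gives 4500 nM. Compound 3 is therefore expected to lie near 3500 nM, within 1000 nM to 12000 nM.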

Compound 3, half-maximal inhibitory concentration: 800 nM
The estimate for compound 3 lay 4.4-fold (0.64 log units) above the measured number; measured number below the stated range.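

In this assay, chloro in place of hydrogen on an aromatic carbon gives a 5.6-fold lower number from compound 2 to compound 3 (0.75 log units; beyond the scatter), a step beyond the scatter, so this benzyl group on the amine nitrogen responds to a single added ring substituent. The step from compound 1 cannot be read, so pyridin-4-yl remains unplaced against either benzyl group. Nothing shown explains why the number falls. Going by these compounds, whether fluoro or methyl in place of the chloro would shift the number stays open, as does the effect of a carboxylic acid in place of the methoxycarbonyl group.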